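The source may hold more compounds than are shown below. What is called first, only, known or untested is meant among the compounds shown, and "the series" means these compounds.

Among the three compounds measured so far in a physicochemical assay for lipophilicity, using the shake flask method, at pH 7.4 (a lower number here means a more polar compound, a higher number a more lipophilic compound), compound 3 `CC(C)(C)C(Oc1ccc(-n2cc(C(F)(F)F)cn2)cc1)c1ccc(C(=O)NCCC(=O)O)cc1` stands highest, at 3.7. Compound 2 `CCC(Oc1ccc(-n2cc(C(F)(F)F)cn2)cc1)c1ccc(C(=O)NCCC(=O)O)cc1` gives 1.9, and compound 1 `CCCC(Oc1ccc(-n2cc(C(=O)N(C)C)cn2)cc1)c1ccc(C(=O)NCCC(=O)O)cc1` gives 0.5, the lowest number of the three. The next compound, compound 4 `CCCC(Oc1ccc(-n2cc(C(F)(F)F)cn2)cc1)c1ccc(C(=O)NCCC(=O)O)cc1`, is derived from compound 3 by a single change propyl in place of tert-butyl on a saturated chain carbon bound to an aromatic carbon and an oxygen on an aromatic ring.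

Among the measured compounds shown here, one measured step bears directly on this change. At the same place, with the rest of the structure unchanged, the replacement of ethyl by tert-butyl gave a number 1.80 log units higher from compound 2 to compound 3 (beyond the scatter), a large step beyond the scatter. For the measured compounds named here, no measured step connects compound 1 to compound 4, so compound 1 serves here only as a lower reference point.

Removing tert-butyl from compound 3 should therefore reverse much of that rise, though probably not all of it, since propyl is not the ethyl of compound 2. A clear fall is expected in this assay, with an estimated step of a number 1.30 log units lower from compound 3 to compound 4 (beyond the scatter). For compound 4 the expected value is 2.4, with an estimated range of 1.9 to 3.1.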

Compound 4, distribution coefficient: 2.4
Compound 4: middle estimate and measured number agree at the digits printed; the measured number falls inside the stated range.
By their numbers in this assay, from the lowest: compound 1; then compound 2; then compound 4; then compound 3.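

In this assay, the saturated chain carbon bound to an aromatic carbon and an oxygen on an aromatic ring now carries ethyl, propyl or tert-butyl on otherwise identical structures, and compound 4 divides the earlier rise into two unequal parts: the added methyl gives a number 0.50 log units higher from compound 2 to compound 4 (beyond the scatter) and is a modest step, whereas propyl in place of tert-butyl gives a number 1.30 log units lower from compound 3 to compound 4 (beyond the scatter) and is a large one. Among the compounds shown here, compound 4 also brings compound 1 into a one-place comparison for the first time, as trifluoromethyl in place of dimethylcarbamoyl on an aromatic carbon gives a number 1.90 log units higher from compound 1 to compound 4 (beyond the scatter) with propyl held on the chain carbon, another large step. No accompanying measurement accounts for the size of any of these steps.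

From the compounds shown here alone, whether the trifluoromethyl step keeps its size with ethyl or tert-butyl on the chain carbon remains open. So does where a longer chain such as butyl, a branched isopropyl or a cyclopropyl ring at the same place would fall relative to these three groups.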